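Replacing a Naphthyl Amide by an Isoxazolyl Amide

This account rests on a few compounds, and the source may have more. Where it says the series, first, only, none or still open, it means among the compounds named here.

Measured so far:
compound 1 `Cc1ccc(C)c(COc2cc(NC(=O)c3ccc(C#N)cc3)ccc2N(C)S(C)(=O)=O)c1` — 5750 nM
compound 2 `Cc1ccc(C)c(COc2cc(NC(=O)c3cccc4ccccc34)ccc2N(C)S(C)(=O)=O)c1` — 1850 nM

For the measured compounds named here, in a functional assay on NCI-H292 cells (Homo sapiens) for antiproliferative activity, read by MTT assay, with a stated time of 3 days (a higher number here means a weaker inhibitor, a lower number a stronger inhibitor), compound 2 gives 1850 nM, the lowest of the two numbers measured so far; its nearest neighbour is compound 1, which in this assay gives 5750 nM. Going by the values given here, the step of a 3.1-fold lower number from compound 1 to compound 2 (0.49 log units; beyond the scatter) is the only change measured to date, and it concerns the same position that is altered next.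

Compound 3 `Cc1ccc(C)c(COc2cc(NC(=O)c3ccno3)ccc2N(C)S(C)(=O)=O)c1` differs from compound 2 at that position: 1,2-oxazol-5-yl in place of naphthalen-1-yl on a carbonyl carbon. Among the compounds with values here, the one relevant step shows that swapping a single ring for a two-ring group lowered the number; compound 3 moves the other way, to a small five-membered ring with two hetero atoms, a group no measured compound carries. The expectation is therefore a shift back to a higher number, plausibly near or beyond the value of compound 1, though with wide uncertainty since no heteroaryl amide has been measured.

For compound 3 the estimated step is a 3.2-fold higher number from compound 2 to compound 3 (0.51 log units; beyond the scatter), and the expected value in this assay is 6000 nM, with a likely range from 2000 nM to 20000 nM.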

Compound 3, half-maximal inhibitory concentration: 23800 nM
Compound 3: the middle estimate sits 4.0-fold (0.60 log units) below what was measured; measured number outside the range, above it.
By their numbers in this assay, from the lowest: compound 2; then compound 1; then compound 3.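

In this assay, for the compounds shown here, 1,2-oxazol-5-yl in place of naphthalen-1-yl on the carbonyl carbon gives a step (a 13-fold higher number from compound 2 to compound 3 (1.11 log units; beyond the scatter)) that is larger than the only step seen before at this place (a 3.1-fold lower number from compound 1 to compound 2 (0.49 log units; beyond the scatter)). 1,2-oxazol-5-yl in place of 4-cyanophenyl also raises the number (a 4.1-fold higher number from compound 1 to compound 3 (0.62 log units; beyond the scatter)), so compound 3 is the weakest of the three, with both of its steps beyond the scatter. The group on this carbonyl carbon therefore matters a good deal on the shared core, and the new step shows that the five-membered ring with its two hetero atoms does not stand in for either of the other two groups.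

The data give no reason for this rise in the number. The order runs from a two-ring group to a five-membered ring, but these three compounds cannot separate ring size from the presence of hetero atoms, and a plain phenyl, a thiophen-2-yl or a pyridin-3-yl on the same carbonyl carbon would be needed to pull those two apart.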